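A Nitrophenylsulfonyl Variant of Compound 1

The source may hold more compounds than are shown below. What is called first, only, known or untested is meant among the compounds shown, and "the series" means these compounds.

Measured so far:
compound 1 `N#CC1=C(NC(=S)Nc2ccc(Cl)cc2)N(c2ccc(S(N)(=O)=O)cc2)C2=C(C(=O)CCC2)C1c1ccc(Cl)cc1Cl` — 40 ug/mL
compound 2 `N#CC1=C(NC(=S)Nc2ccc(Br)cc2)N(c2ccc(S(N)(=O)=O)cc2)C2=C(C(=O)CCC2)C1c1ccc(Cl)cc1Cl` — 25 ug/mL
compound 3 `N#CC1=C(N2C(=O)CCC2=O)N(c2ccc(S(N)(=O)=O)cc2)C2=C(C(=O)CCC2)C1c1ccc(Cl)cc1Cl` — 25 ug/mL

In a functional assay on Ehrlich cells (Mus musculus) for cytotoxicity, read by trypan blue exclusion, with a stated time of 2 h (a higher number here means a weaker inhibitor, a lower number a stronger inhibitor), compound 1 gives 40 ug/mL, the highest of the three numbers recorded, yet every neighbour lies within the scatter of it: a 1.6-fold lower number from compound 1 to compound 2 (0.20 log units; within the scatter) and a 1.6-fold lower number from compound 1 to compound 3 (0.20 log units; within the scatter). Compound 2 and compound 3 stand together as well, with no change at the digits printed from compound 2 to compound 3 (within the scatter).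

Compound 4 `N#CC1=C(NS(=O)(=O)c2ccc([N+](=O)[O-])cc2)N(c2ccc(S(N)(=O)=O)cc2)C2=C(C(=O)CCC2)C1c1ccc(Cl)cc1Cl` has not yet been measured. It differs from compound 1 in one place: a group of 12 heavy atoms (6 carbon, 1 nitrogen, 4 oxygen, 1 sulfur; one six-membered aromatic ring of carbon only) in place of a group of 10 heavy atoms (7 carbon, 1 nitrogen, 1 sulfur, 1 chlorine; one six-membered aromatic ring of carbon only), on an amine nitrogen. For the measured compounds named here, no measured step replaces the same group with a sulfonyl-bearing substituent, so the nearest guidance comes from the step from compound 1 to compound 3, in which a group on the double-bonded ring carbon was exchanged for a five-membered ring without the number moving beyond the scatter, and from the halogen swap between compound 1 and compound 2, which also stayed within it. The changes seen so far, whether small or large in atoms, have left this assay essentially unmoved.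

On that basis compound 4 is expected to sit close to compound 1, with the estimated step of a 1.3-fold lower number from compound 1 to compound 4 (0.12 log units; within the scatter) not beyond the scatter. The estimate for compound 4 in this assay is 30 ug/mL, with a range from 12 ug/mL to 75 ug/mL.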

Compound 4, half-maximal inhibitory concentration: 20 ug/mL
Beside the measured number, compound 4's estimate is 1.5-fold (0.18 log units) above it, within the range that was stated.
By their numbers in this assay, from the lowest: compounds 4, 2, 3 and 1 (each within the scatter of the next).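

In this assay, the (4-nitrophenyl)sulfonyl group on the amine nitrogen gives a 2.0-fold lower number from compound 1 to compound 4 (0.30 log units; within the scatter) and a 1.3-fold lower number from compound 2 to compound 4 (0.10 log units; within the scatter), so a sulfonyl-bearing group can take this place with the number still inside the scatter of both thiourea-bearing compounds. The earlier compounds shown here showed only a halogen swap on the aromatic ring and a five-membered ring on the double-bonded ring carbon; here the group that enters carries 0 hydrogen-bond donors and 4 hydrogen-bond acceptors, where the group that leaves carries 1 of each, and this assay's number still does not move beyond the scatter. No measurement is available that would explain this tolerance.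

The compounds shown leave open whether a plain amine, an acetyl group or a methanesulfonyl group on this nitrogen would also stay within the scatter, or whether any group here can move the number beyond it. They also leave open whether an amine or a carboxylic acid in place of the nitro group on the (4-nitrophenyl)sulfonyl group would change the reading.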